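Acetylpiperazine in place of piperidine on the shared core

The source may report more compounds than this note shows. Statements on the series, on what has been measured and on what is new or still open speak of the compounds shown alone.

Compounds measured so far in a functional assay on MV4-11 cells (Homo sapiens) for inhibition, read by luminescence, with a stated time of 72 h; a lower number here means a stronger inhibitor, a higher number a weaker inhibitor:
compound 1, `CCN1CCN(Cc2cc(Nc3ncc(F)c(-c4ccc(F)cc4OC)n3)cc3c2OCC(=O)N3CC)CC1`, gives 142 nM
compound 2, `CCN1C(=O)COc2c(CN3CCN(C(C)C)CC3)cc(Nc3ncc(F)c(-c4ccc(F)cc4OC)n3)cc21`, gives 149 nM
compound 3, `CCN1C(=O)COc2c(CN3CCCCC3)cc(Nc3ncc(F)c(-c4ccc(F)cc4OC)n3)cc21`, gives 50 nM

Compound 3 has the lowest number of the three in this assay. Its nearest neighbour is compound 1, reached by a 2.8-fold lower number from compound 1 to compound 3 (0.45 log units; beyond the scatter), and the step of a 3.0-fold lower number from compound 2 to compound 3 (0.47 log units; beyond the scatter) is of much the same size, both beyond the scatter, so compound 3 stands apart from the other two. Between compound 1 and compound 2 the step of a 1.0-fold higher number from compound 1 to compound 2 (0.02 log units; within the scatter) lies within the scatter.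

The next compound, compound 4, `CCN1C(=O)COc2c(CN3CCN(C(C)=O)CC3)cc(Nc3ncc(F)c(-c4ccc(F)cc4OC)n3)cc21`, changes only the group on the saturated chain carbon bound to an aromatic carbon: 4-acetylpiperazin-1-yl in place of piperidin-1-yl on a saturated chain carbon bound to an aromatic carbon.

The two steps that bear on this are the ones that brought the piperidin-1-yl group in, from compound 1 and from compound 2, both of which lowered the number modestly. Compound 4 returns to a piperazine ring carrying a substituent, so the author expects the reverse: a modest rise in this assay, of about the size seen in those two steps, expressed as a 2.8-fold higher number from compound 3 to compound 4 (0.45 log units; beyond the scatter). The estimate for compound 4 in this assay is therefore 140 nM, with a range of 60 nM to 350 nM.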

Compound 4, half-maximal inhibitory concentration: 17 nM
Beside the measured number, compound 4's estimate is 8.2-fold (0.92 log units) above it, outside the stated range (below it).
By their numbers in this assay, from the lowest: compound 4; then compound 3; then compounds 1 and 2 (each within the scatter of the next).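

In this assay, a substituted piperazine at this place is not in itself a drawback, since the change from piperidin-1-yl to 4-acetylpiperazin-1-yl gives a 2.9-fold lower number from compound 3 to compound 4 (0.47 log units; beyond the scatter) and puts the piperazine ring on the low side of the piperidine. The group on the ring amine nitrogen now matters clearly: ethyl and isopropyl could not be told apart in a 1.0-fold higher number from compound 1 to compound 2 (0.02 log units; within the scatter) but acetyl in their place gives an 8.4-fold lower number from compound 1 to compound 4 (0.92 log units; beyond the scatter) and an 8.8-fold lower number from compound 2 to compound 4 (0.94 log units; beyond the scatter) as the largest steps among these compounds. The lower number for piperidin-1-yl therefore holds only against the ethyl and isopropyl piperazines of compound 1 and compound 2, and compound 4 goes against any wider reading of it.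

On these data alone, it remains open whether a longer acyl chain, a methanesulfonyl group or a plain hydrogen on that ring nitrogen would follow acetyl or instead follow ethyl and isopropyl. Nothing measured here accounts for the lower number that comes with the acetyl group.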